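Series notes: replacing the 2-bromophenyl group in compound 2

The source may report more compounds than this note shows. Statements on the series, on what has been measured and on what is new or still open speak of the compounds shown alone.

Measured so far:
- compound 1 `CN(Cc1ccc(F)cc1)C(=O)c1cc2c(Cc3ccccc3)n[nH]c2cc1O` at 4100 nM
- compound 2 `Cc1cccc(Cc2n[nH]c3cc(O)c(C(=O)N(C)Cc4ccccc4Br)cc23)c1` at 310 nM

Within the data shown here, in a functional assay on A2780 cells (Homo sapiens) for antiproliferative activity, read by resazurin assay, with a stated time of 72 h (on this read-out higher numbers stand for weaker inhibition and lower numbers for stronger inhibition), compound 2 gives 310 nM, the lower of the two numbers and beyond the scatter of the only other measured compound. Compound 1 and compound 2 differ in more than one place, so the gap between them cannot be assigned to any single change.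

The next compound is compound 3 `Cc1cccc(Cc2n[nH]c3cc(O)c(C(=O)N(C)Cc4ccc(F)cc4)cc23)c1`. It departs from compound 2 in one place: 4-fluorophenyl in place of 2-bromophenyl on a saturated chain carbon bound to an amide-type nitrogen. In words, 4-fluorophenyl stands in place of 2-bromophenyl on a saturated chain carbon bound to an amide-type nitrogen. Among the measured compounds shown here, no measured single-place step is available as a guide. For the measured compounds named here, the only measured compound with the entering 4-fluorophenyl group is compound 1, at 4100 nM, and this points towards weaker inhibition. The expected change is therefore a loss of inhibition beyond the scatter, estimated as a 4.2-fold higher number from compound 2 to compound 3 (0.62 log units; beyond the scatter). For compound 3 the expected value is 1300 nM, with an estimated range of 450 nM to 3800 nM.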

Compound 3, half-maximal inhibitory concentration: 590 nM
Compound 3: the middle estimate sits 2.2-fold (0.34 log units) above what was measured, and the stated range covers the measured number.
By their numbers in this assay, from the lowest: compounds 2 and 3 (each within the scatter of the next); then compound 1.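

In this assay, a 1.9-fold higher number from compound 2 to compound 3 (0.28 log units; within the scatter), so at this position, on a saturated chain carbon bound to an amide-type nitrogen, 4-fluorophenyl and 2-bromophenyl cannot be told apart, and the exchange of one for the other is tolerated. Among these compounds, with the 4-fluorophenyl group held constant, the single change of methyl in place of hydrogen on an aromatic carbon gives a 6.9-fold lower number from compound 1 to compound 3 (0.84 log units; beyond the scatter), and of the two single-place steps now available, only this one lies beyond the scatter. No measurement bearing on the origin of either step is available.

The two groups at this position differ both in the halogen and in where it sits on the ring, so the contribution of each remains unresolved, and a within-scatter step between two halogen-bearing phenyl groups says little about the wider tolerance of this position. As far as these compounds go, it remains open whether the number would hold with an unsubstituted phenyl, a pyridine ring or an aliphatic amine in place of these groups, and whether the effect of the methyl group would carry over to compounds with the 2-bromophenyl group.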